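Aryl exchange on the core of compound 1

The compounds below may be only part of what the source reports. "The series", "measured", "known", "first", "only" and "open" are said of these compounds alone.

Compound 1 `CCOC(=O)c1cnn(-c2nc(-c3ccccc3Cl)c(C#N)c(=O)n2C)c1N` is the weaker of the two measured entries: in a functional assay, with a stated time of 150 min (on this read-out higher numbers stand for weaker inhibition and lower numbers for stronger inhibition), compound 1 gives 93 ug/mL. Compound 2 `Cn1c(NN)nc(-c2ccc(Cl)cc2)c(C#N)c1=O` gives 59 ug/mL in this assay, a number within the scatter of that of compound 1, so the two cannot be ordered. Going by the values given here, compound 2 differs from compound 1 at several places, so no single step between them can be read.

Compound 3 `CCOC(=O)c1cnn(-c2nc(-c3ccc(OC)cc3)c(C#N)c(=O)n2C)c1N` has not been measured in this assay. It keeps the core of compound 1 and changes one group on an aromatic carbon: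

4-methoxyphenyl in place of 2-chlorophenyl on an aromatic carbon

Among the compounds with values here, no measured pair shows what such an exchange does in this assay. With nothing to rest on but the two measured numbers, no step beyond the scatter is expected in either direction: the step of a 1.0-fold lower number from compound 1 to compound 3 (0.01 log units; within the scatter) is expected to be small. Compound 3 is estimated at 90 ug/mL, with a range from 40 ug/mL to 200 ug/mL.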

Compound 3, half-maximal inhibitory concentration: 79 ug/mL
For compound 3 the middle estimate is 1.1-fold (0.06 log units) above the measured one, and the stated range covers the measured number.
By their numbers in this assay, from the lowest: compounds 2, 3 and 1 (each within the scatter of the next).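

Going by these compounds alone, this is the first step that can be read at one place: on the aromatic carbon ortho to a cyano group, 4-methoxyphenyl in place of 2-chlorophenyl gives a 1.2-fold lower number from compound 1 to compound 3 (0.07 log units; within the scatter) in this assay. At this carbon, then, the two aryl groups cannot be told apart on this read-out, even though the entering group differs in both its substituent and that substituent's place on the phenyl ring. Nothing at hand explains this result.

As far as these compounds go, with only these two aryl groups read on the shared core, it remains open whether any group at this carbon gives a step beyond the scatter, for example a piperidine amine or a pyridine ring. The same question stands for a carboxylic acid in place of the ethyl ester.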